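Swapping the fluorinated phenyl group of compound 2

A few compounds are considered here, and "the series" means these few. Any claim that something is new, unique, unknown or untested is made for them only; others in the source may bear on it.

In a functional assay with Homo sapiens as the target (on this read-out lower numbers stand for stronger inhibition and higher numbers for weaker inhibition), the measured compounds are:
Compound 1 `CC(C)[C@H](NC(=O)COc1cccc2ccccc12)C(=O)N[C@@H](CC(=O)O)C(=O)COc1ccc(F)c(F)c1F` gives 20600 nM
Compound 2 `CC(C)[C@H](NC(=O)COc1cccc2ccccc12)C(=O)N[C@@H](CC(=O)O)C(=O)COc1cc(F)c(F)cc1F` gives 16700 nM

Among the compounds with values here, compound 2 stands level with compound 1, the only other compound measured. Compound 3 `CC(C)[C@H](NC(=O)COc1cccc2ccccc12)C(=O)N[C@@H](CC(=O)O)C(=O)COc1cccc(C(F)(F)F)c1F` carries 2-fluoro-3-(trifluoromethyl)phenyl in place of 2,4,5-trifluorophenyl on an oxygen on a saturated carbon. Within the data shown here, the one measured step that bears on this, a 1.2-fold lower number from compound 1 to compound 2 (0.09 log units; within the scatter) from one trifluorophenyl group to another, stays small, and no measured compound carries trifluoromethyl. No shift beyond the scatter is therefore expected, in either direction. An estimated 1.1-fold lower number from compound 2 to compound 3 (0.05 log units; within the scatter) is expected here. For compound 3 the estimated value is 15000 nM with an expected range of 6000 nM to 40000 nM in this assay.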

Compound 3, half-maximal inhibitory concentration: 18200 nM
Compound 3: middle estimate off by 1.2-fold (0.08 log units), on the low side; the measured number falls inside the stated range.
By their numbers in this assay, from the lowest: compounds 2, 3 and 1 (each within the scatter of the next).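

In this assay, within the data shown here, trifluoromethyl appears at this position for the first time, and the read-out stays level, with a 1.1-fold higher number from compound 2 to compound 3 (0.04 log units; within the scatter) and a 1.1-fold lower number from compound 1 to compound 3 (0.05 log units; within the scatter). The position therefore takes 2-fluoro-3-(trifluoromethyl)phenyl, with its 11 heavy atoms, in place of either trifluorophenyl group, with 9, without a step beyond the scatter. No measurement at hand explains this level result. On these data alone, all three compounds carry a fluorinated phenyl on this oxygen, so what an amine or a carboxylic acid on that ring would do stays open. As far as these compounds go, whether any change here reaches beyond the scatter also remains open.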